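Removing Both Fluorines From Compound 1's Benzoyl Group

The source may report more compounds than this note shows. Statements on the series, on what has been measured and on what is new or still open speak of the compounds shown alone.

Measured compounds:
Compound 1, `CC(C)NC(=O)[C@H]1CC[C@@H](n2/c(=N/C(=O)c3ccc(F)c(F)c3)[nH]c3ccc(CN4CCC(C(C)(C)O)CC4)cc32)CC1` — 60 mL.min-1.g-1
Compound 2, `CC(C)NC(=O)[C@H]1CC[C@@H](n2/c(=N/C(=O)c3ccc(F)cc3)[nH]c3ccc(CN4CCCCC4)cc32)CC1` — 302 mL.min-1.g-1
Compound 3, `CC(C)NC(=O)[C@H]1CC[C@@H](n2/c(=N/C(=O)c3ccc(F)cc3)[nH]c3ccc(CN4CC(C(C)(C)O)C4)cc32)CC1` — 105 mL.min-1.g-1

In an in vitro ADME assay on microsomes from liver (Homo sapiens) for metabolic stability (on this read-out lower numbers stand for slow clearance and higher numbers for fast clearance), compound 1 gives the lowest of the three numbers. Its nearest neighbour is compound 3, and the gap between them lies within the usual scatter. Compound 2 stands furthest away, beyond the scatter. Within the data shown here, the one measured step, a 2.9-fold lower number from compound 2 to compound 3 (0.46 log units; beyond the scatter), concerns the group on the saturated chain carbon and not the aromatic ring on the carbonyl.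

Compound 4, `CC(C)NC(=O)[C@H]1CC[C@@H](n2/c(=N/C(=O)c3ccccc3)[nH]c3ccc(CN4CCC(C(C)(C)O)CC4)cc32)CC1`, differs from compound 1 in that ring: phenyl in place of 3,4-difluorophenyl on a carbonyl carbon. Among the measured compounds shown here, no measured step touches this part of the molecule, so nothing here sets the size or the direction of the change. For the measured compounds named here, with no supporting step, the number for compound 4 is expected to stay close to that of compound 1, with a 1.3-fold higher number from compound 1 to compound 4 (0.12 log units; within the scatter) lying within the scatter. Compound 4 is estimated at 80 mL.min-1.g-1, with a range from 40 mL.min-1.g-1 to 160 mL.min-1.g-1.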

Compound 4, intrinsic clearance in microsomes: 40 mL.min-1.g-1
The estimate for compound 4 lay 2.0-fold (0.30 log units) above the measured number; low and high end bracket the measured number.
By their numbers in this assay, from the lowest: compounds 4, 1 and 3 (each within the scatter of the next, the first and the last beyond it); then compound 2.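

In this assay, the change from 3,4-difluorophenyl to phenyl on the carbonyl carbon gives a 1.5-fold lower number from compound 1 to compound 4 (0.18 log units; within the scatter), so this read-out does not separate the two rings in this pair. Among these compounds, this is the first measured step at this position, and it shows that removing both fluorines leaves the number of the compound within the scatter while the rest of the molecule stays fixed. No measurement shown here accounts for this result.

The compounds shown leave open whether a single fluorine on this ring would also leave the number within the scatter in the same setting. They also leave open whether a different group on the carbonyl carbon, such as a methoxyphenyl or pyridyl ring, would move the number beyond it.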